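This account rests on a few compounds, and the source may have more. Where it says the series, first, only, none or still open, it means among the compounds named here.

Of the compounds shown here, two of the same core have been measured in an assay on CHO cells for displacement of a labelled ligand from histamine receptor H3 (Macaca mulatta); a lower number here means a stronger inhibitor, a higher number a weaker inhibitor. Compound 1 `Cc1cc(N2CC[C@H](N3CCC[C@@H]3C)C2)ccc1NC(=O)C1CCCO1` gives 7.33 nM. Compound 2 `CC(=O)N1CCCC1C(=O)Nc1ccc(N2CCC(N3CCCC3C)C2)cc1` gives 14.1 nM. Compound 1 stands at the lower of the two numbers, with compound 2 a little higher, yet the two values lie within the usual scatter of repeated measurements, so nothing can be said about any order between them. Among the compounds with values here, both carry a five-membered ring containing one oxygen or one nitrogen on the amide side of the core, so the two measured values are the only guide to what that side tolerates.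

Compound 3 `Cc1cc(N2CC[C@H](N3CCC[C@@H]3C)C2)ccc1NC(=O)C1C(C)(C)C1(C)C` is not yet measured. It differs from compound 1 in one place: 2,2,3,3-tetramethylcyclopropyl in place of oxolan-2-yl on a carbonyl carbon. The group entering is all carbon and carries no hydrogen-bond acceptor, whereas the group leaving carries one. Within the data shown here, no measured pair shows this kind of change, so no step size can be read off. A step from compound 1 to compound 3 of a 1.6-fold higher number from compound 1 to compound 3 (0.21 log units; within the scatter) in this assay is expected, a small shift toward a higher number but not clearly beyond the scatter. Compound 3 is estimated at 12 nM, with a range from 3 nM to 50 nM.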

Compound 3, inhibition constant: 0.55 nM
For compound 3 the middle estimate is 22-fold (1.34 log units) above the measured one; measured number below the stated range.
By their numbers in this assay, from the lowest: compound 3; then compounds 1 and 2 (each within the scatter of the next).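

In this assay, putting 2,2,3,3-tetramethylcyclopropyl in place of oxolan-2-yl on the carbonyl carbon gives a 13-fold lower number from compound 1 to compound 3 (1.12 log units; beyond the scatter), a large step that lies well beyond the scatter of repeated measurements. The two earlier compounds could not show this, since their values lay within the scatter of each other; this pair shows that the group on this carbonyl carbon can shift the number strongly, and that a low number here does not require a hydrogen-bond acceptor in that group, as the entering group, made of carbon only, has none. Nothing in the data shown accounts for the size of this step.

The change alters several things at once, including the ring size, the number of heavy atoms and the presence of the ring oxygen, so this single pair cannot say which of them matters. A plain cyclopropyl group without the four methyl groups, or a cyclopentyl group, which has the ring size of oxolan-2-yl but only carbon in the ring, would begin to separate these features.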